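From compound 2 to compound 4: one fluoro added

The source may hold more compounds than are shown below. What is called first, only, known or untested is meant among the compounds shown, and "the series" means these compounds.

Measured in a physicochemical assay for solubility; a lower number here means a less soluble compound, a higher number a more soluble compound:
compound 1 `COc1ccc(-n2cnc3cnc(Oc4cccc(NC(C)=O)c4)cc32)cc1OC`: > 200000 nM (a limit of the assay)
compound 2 `COc1ccc(-n2cnc3cnc(-c4ccccc4C)cc32)cc1OC`: > 200000 nM (a limit of the assay)
compound 3 `COc1ccc(-n2cnc3cnc(-c4ccccc4OC(F)(F)F)cc32)cc1OC`: 157000 nM

Compound 2 has no number of its own in this assay, only the limit > 200000 nM. The same ceiling applies to compound 1, as the record shows: the limit of > 200000 nM in this assay, at which 2 of the 3 values shown sit.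

Compound 4 `COc1ccc(-n2cnc3cnc(-c4ccc(F)cc4C)cc32)cc1OC` differs from compound 2 by fluoro in place of hydrogen on an aromatic carbon. The new atom sits meta to a methyl group and para to a large group, turning 2-methylphenyl into 4-fluoro-2-methylphenyl.

Among the compounds with values here, no measured step adds fluoro. Within the data shown here, the only step available puts trifluoromethoxy in place of methyl on an aromatic carbon, and it gave an at least 1.2-fold lower number from compound 2 to compound 3 (0.10 log units; that floor lies within the scatter). That single step is weak evidence, and it supports no expected change beyond the scatter in either direction. Read on that basis, the expected step is an at least 1.1-fold lower number from compound 2 to compound 4 (0.07 log units; that floor lies within the scatter). The assay may again report only a limit. Compound 4 is estimated at 170000 nM, with an expected range from 90000 nM to 200000 nM.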

Compound 4, solubility: > 200000 nM
Compound 4: no number, only a limit; the forecaster's own chance of this, stated with the estimate: 40%; middle value at least 1.1-fold (0.07 log units) from the limit.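

In this assay compound 4 gives > 200000 nM, which is a limit of the assay. Compound 2 also gives only a limit, > 200000 nM. No step from one to the other can be read: the limit of > 200000 nM in this assay, at which 3 of the 4 values shown sit.

The compounds shown leave open whether fluoro in place of hydrogen on an aromatic carbon changes the number in this assay at all, and in which direction.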